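Replacing 4-methoxyphenyl: compound 1 to compound 3

A few compounds are considered here, and "the series" means these few. Any claim that something is new, unique, unknown or untested is made for them only; others in the source may bear on it.

Among the measured compounds shown here, in a functional assay on HCT-116 cells (Homo sapiens) for inhibition, read by MTT assay, with a stated time of 72 h (on this read-out higher numbers stand for weaker inhibition and lower numbers for stronger inhibition), compound 1 (`COc1ccc(CNCc2c(OC)cc(Oc3cccc(Nc4ccccc4)c3)cc2OC)cc1`) gives 2620 nM, the only true number so far in this small set. Compound 2 (`CNCc1c(OC)cc(Oc2cccc(Nc3ccccc3)c2)cc1OC`) reads > 20000 nM, which is a limit of the assay and not a number.

Compound 3 (`COc1cc(Oc2cccc(Nc3ccccc3)c2)cc(OC)c1CNCCNC(C)=O`) has not yet been measured. Its difference from compound 1 is acetamidomethyl in place of 4-methoxyphenyl on a saturated chain carbon bound to an amine nitrogen.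

For the measured compounds named here, one measured step bears on this change, at the same place: an at least 7.6-fold higher number from compound 1 to compound 2 (0.88 log units; beyond the scatter), beyond the scatter, with hydrogen in place of 4-methoxyphenyl. Going by the values given here, compound 3 also lacks the 4-methoxyphenyl but carries acetamidomethyl instead of hydrogen, and no measured compound shows what that group does. On the strength of an at least 7.6-fold higher number from compound 1 to compound 2 (0.88 log units; beyond the scatter), a modest to sizeable move toward weaker inhibition is expected in this assay, and compound 3 may also end at the limit of > 20000 nM in this assay, at which 1 of the 2 values shown sits.

The expected change is a 4.2-fold higher number from compound 1 to compound 3 (0.62 log units; beyond the scatter). Compound 3 is estimated at 11000 nM, with an expected range of 3500 nM to 30000 nM.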

Compound 3, half-maximal inhibitory concentration: 18200 nM
For compound 3 the middle estimate is 1.7-fold (0.22 log units) below the measured one; the measured number falls inside the stated range.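

In this assay, among the compounds shown here, a second replacement of 4-methoxyphenyl on a saturated chain carbon bound to an amine nitrogen now gives a true number rather than a limit, so the loss at this position can be sized for the first time: a 6.9-fold higher number from compound 1 to compound 3 (0.84 log units; beyond the scatter). Acetamidomethyl, with no ring and one hydrogen-bond donor, does not hold the level of compound 1, and both compounds shown without the 4-methoxyphenyl read weaker than compound 1, with none going against this in so small a set. The value of compound 2 is a limit and not a number: the limit of > 20000 nM in this assay, at which 1 of the 3 values shown sits. The step that acetamidomethyl in place of hydrogen gives is therefore only a floor: an at least 1.0-fold lower number from compound 2 to compound 3 (0.04 log units; that floor lies within the scatter).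

The compounds shown leave open whether an unsubstituted phenyl, a 4-chlorophenyl or a pyridine ring in the same place would hold the level of compound 1, which would separate the part played by the aromatic ring from that of its methoxy group. Also open, going by these compounds, is whether a primary amine or a carboxylic acid at the end of a longer chain would read any differently from acetamidomethyl.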